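This account rests on a few compounds, and the source may have more. Where it says the series, first, only, none or still open, it means among the compounds named here.

Measured so far in a functional assay on DWD cells (Homo sapiens) for inhibition, read by sulforhodamine B assay; a higher number here means a weaker inhibitor of growth, a lower number a stronger inhibitor of growth:
- compound 1 `Cc1ccc2[nH]c(-c3ccc(-c4ccc(-c5cccc(Cl)c5)cc4)cc3)nc2c1` gives 2510 nM
- compound 2 `Fc1ccc(-c2ccc(-c3ccc(-c4nc5ccccc5[nH]4)cc3)cc2)cc1` gives 35600 nM
- compound 3 `Oc1cccc2[nH]c(-c3ccc(-c4ccc(-c5ccc(F)cc5)cc4)cc3)nc12` gives 22200 nM

Compound 3 lies within the scatter of compound 2, so the two cannot be told apart here. Its number is higher than that of compound 1 by more than the scatter, which makes it a weak growth inhibitor within this small set.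

The next compound is compound 4 `Oc1ccc(-c2ccc(-c3ccc(-c4nc5c(O)cccc5[nH]4)cc3)cc2)cc1`, which keeps the frame of compound 3 but carries hydroxy in place of fluoro on an aromatic carbon. In counted terms the change reads hydroxy in place of fluoro on an aromatic carbon in full, turning 4-fluorophenyl into 4-hydroxyphenyl.

Going by the values given here, no measured pair shows this swap directly. The nearest guide is a 1.6-fold lower number from compound 2 to compound 3 (0.21 log units; within the scatter) for hydroxy in place of hydrogen on an aromatic carbon, at a different place in the molecule. Compound 1 differs from the others in more than one place, so it says little about a single swap.

Among the compounds with values here, with only that one small step to go on, no shift beyond the scatter is expected in this assay, and no direction can be favoured. The estimated change is a 1.1-fold lower number from compound 3 to compound 4 (0.05 log units; within the scatter) and this remains uncertain. For compound 4 the estimated value is 20000 nM with an expected range from 7000 nM to 55000 nM in this assay.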

Compound 4, concentration for 50% growth inhibition: 2700 nM
Compound 4: middle estimate off by 7.4-fold (0.87 log units), on the high side; the whole stated range lies above it.
By their numbers in this assay, from the lowest: compounds 1 and 4 (each within the scatter of the next); then compounds 3 and 2 (each within the scatter of the next).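

In this assay, replacing 4-fluorophenyl with 4-hydroxyphenyl gives a step beyond the scatter (an 8.2-fold lower number from compound 3 to compound 4 (0.91 log units; beyond the scatter)) and so shows that the group on this aromatic carbon, para to a large group, can alter growth inhibition. The earlier hydroxy step (a 1.6-fold lower number from compound 2 to compound 3 (0.21 log units; within the scatter)) lay within the scatter at a different place and involved replacing hydrogen rather than fluoro, so the two steps together show that a hydroxy group does not give the same result at every place or in every swap on this frame. Nothing available here explains why this swap gives the lower number.

On these data alone, it remains open whether this step depends on the other hydroxy group that compound 3 and compound 4 share on the core, and whether the same swap would give a similar step on a compound without it. As far as these compounds go, it is also open whether the stronger growth inhibition belongs to hydroxy specifically or would also appear with an amine, a methoxy group or a carboxylic acid at the same place.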